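This account rests on a few compounds, and the source may have more. Where it says the series, first, only, none or still open, it means among the compounds named here.

Working notes on the series, read in a functional assay on HepG2 cells (Homo sapiens) for cytotoxicity, read by MTT assay, with a stated time of 72 h; on this read-out lower numbers stand for stronger inhibition and higher numbers for weaker inhibition. Compound 1 `CNC(=O)c1cc(Oc2ccc(NC(=O)c3nn(-c4ccccc4F)c(=O)cc3C)cc2F)ccn1` gives > 40000 nM, and this value is a limit of the assay, not a number. For the measured compounds named here, compound 2 `Cc1cc(=O)n(-c2ccc(Br)cc2F)nc1C(=O)Nc1ccc(Oc2ncnc3ccsc23)cc1` gives 10600 nM, which makes it the only compound so far with a true number, so it has no measured neighbour to be ranked against.

Next in line is compound 3 `Cc1ccc(-n2nc(C(=O)Nc3ccc(Oc4ncnc5ccsc45)cc3)c(C)cc2=O)cc1`, not yet measured in this assay. Compared with compound 2, the change is 4-methylphenyl in place of 4-bromo-2-fluorophenyl on an aromatic nitrogen, with the rest of the structure kept.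

Going by the values given here, no step between measured compounds that differ in one place exists for this series, so the size of this change has no direct precedent. The expectation therefore starts from compound 2 at 10600 nM, with no direction favoured and no shift beyond the scatter. The estimated step is a 1.0-fold higher number from compound 2 to compound 3 (0.02 log units; within the scatter). A wide range is kept, since it rests on a single number. For compound 3 the expected value is 11000 nM, with an estimated range of 4000 nM to 30000 nM.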

Compound 3, half-maximal inhibitory concentration: 25000 nM
Estimate against measurement, compound 3: 2.3-fold (0.36 log units) below; low and high end bracket the measured number.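

For the compounds shown here, with 4-methylphenyl in place of 4-bromo-2-fluorophenyl on the aromatic nitrogen and the rest of the structure kept, this assay gives a 2.4-fold higher number from compound 2 to compound 3 (0.37 log units; beyond the scatter) and so shows that this position can shift the read-out, which the earlier compounds alone could not show. The change removes the bromine and the fluorine and brings in a methyl group together, so the step belongs to the whole exchange and cannot be assigned to any one of these atoms or groups. Compound 3 still gives a true number, while compound 1 carries a limit of the assay and not a number, and that limit marks the end of the readable range here: the limit of > 40000 nM in this assay, at which 1 of the 3 values shown sits.

Whether the bromine or the fluorine accounts for more of the step stays open, since no compound here separates the two on the shared core. Also open, on these data alone, is how a 4-aminophenyl or a 4-carboxyphenyl group on the same nitrogen would read, and whether a step of this size would carry over to other cores.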